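A few compounds are considered here, and "the series" means these few. Any claim that something is new, unique, unknown or untested is made for them only; others in the source may bear on it.

Working notes on the series. Compound 1 `CN(Cc1ccccc1Br)C(=O)c1cc2c(Cc3ccccc3)n[nH]c2cc1O` gives 1200 nM in a functional assay on A2780 cells (Homo sapiens) for antiproliferative activity, read by resazurin assay, with a stated time of 72 h; on this read-out higher numbers stand for weaker inhibition and lower numbers for stronger inhibition. For the measured compounds named here, compound 2 `CN(Cc1ccc(F)cc1)C(=O)c1cc2c(Cc3ccccc3)n[nH]c2cc1O` gives 4100 nM; the one change between them is 4-fluorophenyl in place of 2-bromophenyl on a saturated chain carbon bound to an amide-type nitrogen, and this change produced a 3.4-fold higher number from compound 1 to compound 2 (0.53 log units; beyond the scatter). Compound 3 `CN(Cc1ccccc1Br)C(=O)c1cc2c(Cc3cccc(Cl)c3)n[nH]c2cc1O` gives 130 nM; it differs from compound 1 by chloro in place of hydrogen on an aromatic carbon, which produced a 9.2-fold lower number from compound 1 to compound 3 (0.97 log units; beyond the scatter), and compound 3 stands lowest of the three measured compounds.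

Compound 4 `CN(Cc1ccc(F)cc1)C(=O)c1cc2c(Cc3cccc(Cl)c3)n[nH]c2cc1O` has not yet been measured. It differs from compound 3 by 4-fluorophenyl in place of 2-bromophenyl on a saturated chain carbon bound to an amide-type nitrogen, which is the same change as that from compound 1 to compound 2, made on the core of compound 3 rather than the core of compound 1; the two cores differ by chloro in place of hydrogen on an aromatic carbon.

Going by the values given here, for compound 4 the step is expected to resemble the earlier one, giving a 3.5-fold higher number from compound 3 to compound 4 (0.54 log units; beyond the scatter), because the only comparable pair shows a 3.4-fold higher number from compound 1 to compound 2 (0.53 log units; beyond the scatter); the one measured case and the possibility that the two changes do not simply add give a wide range. Compound 4 is accordingly estimated at 450 nM, with a range from 200 nM to 1000 nM.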

Compound 4, half-maximal inhibitory concentration: 410 nM
Estimate against measurement, compound 4: 1.1-fold (0.04 log units) above; low and high end bracket the measured number.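

In this assay, the change from 2-bromobenzyl to 4-fluorobenzyl on the chloro-bearing core gives a 3.2-fold higher number from compound 3 to compound 4 (0.50 log units; beyond the scatter), and this step matches the one on the core of compound 1: the same change on two cores in this assay, a 3.4-fold higher number (0.53 log units; beyond the scatter) from compound 1 to compound 2 and a 3.2-fold higher number (0.50 log units; beyond the scatter) from compound 3 to compound 4, 1.1-fold (0.03 log units) apart, within the scatter of two such steps. Read the other way round the same square, the chloro change on the 4-fluorobenzyl amide gives a 10-fold lower number from compound 2 to compound 4 (1.00 log units; beyond the scatter), which also matches its earlier counterpart: the same change on two cores in this assay, a 9.2-fold lower number (0.97 log units; beyond the scatter) from compound 1 to compound 3 and a 10-fold lower number (1.00 log units; beyond the scatter) from compound 2 to compound 4, 1.1-fold (0.03 log units) apart, within the scatter of two such steps. Across these four compounds the two changes therefore behave as independent and additive, but this rests on just two cores that differ by a single chloro, and it does not show that the step would carry to a core differing in any other way, nor why the numbers move.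

The compounds shown leave open whether the same independence holds for an amine or a carboxylic acid on the benzyl ring, or for a longer chain in place of the benzyl carbon. They also leave open whether a group such as nitrile or methoxy in place of the chloro would carry the benzyl step unchanged.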